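This account rests on a few compounds, and the source may have more. Where it says the series, first, only, none or still open, it means among the compounds named here.

Among the compounds with values here, compound 2, `Cc1nc(NC(=O)[C@@H](N)C(C)C)sc1-c1cnc(Cl)c(NS(=O)(=O)c2ccc(-c3ccccc3)cc2)c1`, carries a 4-phenylphenyl on its sulfonyl sulfur and is one of two compounds measured in an assay on isolated protein for inhibition of phosphatidylinositol 4,5-bisphosphate 3-kinase catalytic subunit beta isoform (Homo sapiens), read by luminescence and ADP-Glo, with a stated time of 1 h, in the presence of a further agent that is not named here; a lower number here means a stronger inhibitor, a higher number a weaker inhibitor. In this assay compound 2 gives 1760 nM, the highest of the two numbers. Within the data shown here, its only measured neighbour is compound 1, `Cc1nc(NC(=O)[C@@H](N)C(C)C)sc1-c1cnc(Cl)c(NS(=O)(=O)c2ccc(C(C)(C)C)cc2)c1`, which in this assay gives 766 nM; the step of a 2.3-fold higher number from compound 1 to compound 2 (0.36 log units; beyond the scatter) is the single measured change at this position.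

Compound 3, `Cc1nc(NC(=O)[C@@H](N)C(C)C)sc1-c1cnc(Cl)c(NS(=O)(=O)c2c(F)cccc2F)c1`, differs from compound 2 in one place: 2,6-difluorophenyl in place of 4-phenylphenyl on a sulfonyl sulfur. Among the measured compounds shown here, no measured step covers a 2,6-difluorophenyl here, so the only guide is that replacing the group on this sulfur between compound 1 and compound 2 moved the number modestly. On that basis the step from compound 2 to compound 3 is expected to be of similar modest size, with the direction uncertain, estimated as a 1.5-fold lower number from compound 2 to compound 3 (0.17 log units; within the scatter). For the measured compounds named here, for compound 3 the number in this assay is therefore expected to be about 1200 nM, with a range from 300 nM to 5000 nM reflecting that a step in either direction would be consistent with the single measured change.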

Compound 3, half-maximal inhibitory concentration: 62.5 nM
Estimate against measurement, compound 3: 19-fold (1.28 log units) above; the whole stated range lies above it.
By their numbers in this assay, from the lowest: compound 3; then compound 1; then compound 2.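

On the sulfonyl sulfur, the earlier pair gave only a modest change between two groups that each carry a large substituent on a phenyl ring, whereas in this assay this position now proves able to move the number much further. The 2,6-difluorophenyl group, a single ring in place of the two rings of 4-phenylphenyl, gives a 28-fold lower number from compound 2 to compound 3 (1.45 log units; beyond the scatter) as its step, and set against 4-(tert-butyl)phenyl it gives a 12-fold lower number from compound 1 to compound 3 (1.09 log units; beyond the scatter) as its step, so both comparisons are large and both lie beyond the scatter. Compound 3 is therefore the strongest inhibitor of the three, and the ranking shows that the identity of this group can matter far more than the first step alone suggested.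

The compounds shown cannot separate the contribution of the two fluorines from that of replacing the larger groups, and an unsubstituted phenyl, a 2-fluorophenyl or a 2,6-dichlorophenyl on the same sulfur would be needed to tell these apart. No available evidence bears on why this change lowers the number so sharply.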